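Removing the methoxy group from compound 1

The source may report more compounds than this note shows. Statements on the series, on what has been measured and on what is new or still open speak of the compounds shown alone.

Compound 1, `COc1ccc(-c2nc(SCC(=O)c3sc(-c4ccccc4)nc3C)[nH]c(=O)c2C#N)cc1`, is the reference point of this small series. In a functional assay on U-87MG ATCC cells for antiproliferative activity against U-87 MG (Homo sapiens), read by MTT assay, with a stated time of 48 h, tested at 10 uM (a lower number here means a stronger effect, a higher number a weaker effect of the compound at the concentration tested), compound 1 gives 90.4%, the highest of the three numbers measured. Compound 3, `COc1ccc(-c2nc(SCC(=O)c3sc(-c4ccc(Cl)cc4)nc3C)[nH]c(=O)c2C#N)cc1`, gives 88.3% in this assay, and compound 2, `COc1ccc(-c2nc(C)c(C(=O)CSc3nc(-c4ccc(OC)cc4)c(C#N)c(=O)[nH]3)s2)cc1`, gives 80.3% in this assay. The two measured steps from compound 1 are small: a number 10.1 percentage points lower from compound 1 to compound 2 (beyond the scatter), and a number 2.1 percentage points lower from compound 1 to compound 3 (within the scatter).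

The unmeasured compound 4, `Cc1nc(-c2ccccc2)sc1C(=O)CSc1nc(-c2ccccc2)c(C#N)c(=O)[nH]1`, differs from compound 1 by the change (hydrogen in place of methoxy on an aromatic carbon). Going by the values given here, the measured steps alter a different part of the shared core than the change leading to compound 4, so none of them bears on it directly; they show only that substituent changes across the series move this assay by little. Compound 4 is therefore expected to stay close to compound 1, with an expected step of a number 2.4 percentage points lower from compound 1 to compound 4 (within the scatter) in this assay, in no direction beyond the scatter. The estimate for compound 4 is 88%, within a range from 75% to 98%.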

Compound 4, a percentage reported as activity, at one concentration (the size of the read-out at that concentration, not a potency): 87.5%
The estimate for compound 4 lay 0.5 percentage points above the measured number, and the stated range covers the measured number.
By their numbers in this assay, from the lowest: compounds 2, 4, 3 and 1 (each within the scatter of the next, the first and the last beyond it).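

Going by these compounds alone, this is the first measured change at this position: with 4-methoxyphenyl going to phenyl, on a six-membered aromatic ring of carbon only and para to a large group, this assay shows a number 2.9 percentage points lower from compound 1 to compound 4 (within the scatter) at the concentration tested. The assay therefore does not separate methoxy from hydrogen at this place in the setting of compound 1, and the methoxy group is not needed to keep the read-out where it stands. Nothing shown here gives a reason for this result.

The compounds shown leave open whether an amine, a carboxylic acid or a longer alkoxy chain at this place would move the read-out beyond the scatter. They also leave open whether hydrogen in place of methoxy would behave the same way with the substituted aromatic rings of compound 2 or compound 3.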